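The source may hold more compounds than are shown below. What is called first, only, known or untested is meant among the compounds shown, and "the series" means these compounds.

Compound 1 `CCCCOC(=O)c1ccc(COC(COCc2ccc(OC)cc2)Cn2ccnc2)cc1` gives 200 nM. Compound 2 `COc1ccc(COCC(Cn2ccnc2)OCc2ccc(C(=O)Oc3ccccc3)cc2)cc1` gives 560 nM. Compound 3 `CCOC(=O)c1cccc(COC(COCc2ccc(OC)cc2)Cn2ccnc2)c1` gives 7200 nM.

In a functional assay for inhibition of Thromboxane-A synthase (Homo sapiens) (a higher number here means a weaker inhibitor, a lower number a stronger inhibitor), compound 2 stands second highest of the three numbers; the nearest is compound 1, reached through the step of a 2.8-fold higher number from compound 1 to compound 2 (0.45 log units; beyond the scatter), while compound 3 sits far higher. Compound 4 `COc1ccc(COCC(Cn2ccnc2)OCc2ccc(C(=O)O)cc2)cc1` differs from compound 2 in one place: hydrogen in place of phenyl on an oxygen next to a carbonyl group. For the measured compounds named here, the only measured step at that same oxygen is a 2.8-fold higher number from compound 1 to compound 2 (0.45 log units; beyond the scatter), a modest one, and it concerns two esters, not the carboxy group. Going by the values given here, no measured pair touches a hydrogen at this place, so the expectation rests loosely on that one step, and a modest step in either direction is anticipated. Compound 4 is therefore estimated at 350 nM, with a range from 60 nM to 2000 nM. That estimate would mean a 1.6-fold lower number from compound 2 to compound 4 (0.20 log units; within the scatter).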

Compound 4, half-maximal inhibitory concentration: 6700 nM
Estimate against measurement, compound 4: 19-fold (1.28 log units) below, and the stated range ends below it.
By their numbers in this assay, from the lowest: compound 1; then compound 2; then compounds 4 and 3 (each within the scatter of the next).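

In this assay, losing the ester at this oxygen matters far more than exchanging one ester group for another: hydrogen in place of phenyl gives a large step (a 12-fold higher number from compound 2 to compound 4 (1.08 log units; beyond the scatter)), and hydrogen in place of butyl gives a larger one (a 34-fold higher number from compound 1 to compound 4 (1.53 log units; beyond the scatter)), whereas phenyl in place of butyl gave only a modest one (a 2.8-fold higher number from compound 1 to compound 2 (0.45 log units; beyond the scatter)). Among these compounds, both esters therefore give lower numbers than the free carboxy compound 4. Nothing available explains this difference.

From the compounds shown here alone, whether a methyl ester or an amide at this place would stay close to the two esters or close to compound 4 remains open.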